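Capping the Carboxy Group: Compound 1 to Compound 3

The compounds below may be only part of what the source reports. "The series", "measured", "known", "first", "only" and "open" are said of these compounds alone.

Compound 1 `CC(C)(C)[Si](C)(C)O[C@@H]1CCCO[C@@H]1COCC(=O)O`: > 100000 nM
Compound 2 `CC(C)(C)[Si](C)(C)O[C@@H]1CCCO[C@@H]1COCC(=O)OCc1ccccc1`: 28000 nM

In a functional assay on A2780 cells (Homo sapiens) for antiproliferative activity, read by sulforhodamine B assay, with a stated time of 48 h (on this read-out higher numbers stand for weaker inhibition of growth and lower numbers for stronger inhibition of growth), compound 1 gives > 100000 nM. That value is a limit and not a number: the limit of > 100000 nM in this assay, at which 1 of the 2 values shown sits.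

Compound 3 `COC(=O)CCOC[C@H]1OCCC[C@H]1O[Si](C)(C)C(C)(C)C` has not yet been measured. It differs from compound 1 at one place: (methoxycarbonyl)methyl in place of carboxy on a saturated chain carbon bound to an oxygen on a saturated carbon. Here the carboxy group gives way to (methoxycarbonyl)methyl.

Within the data shown here, one measured step bears on this, also a change at the carboxy group: an at least 3.5-fold lower number from compound 1 to compound 2 (0.55 log units; beyond the scatter). The change in this assay is therefore expected to run the same way, an estimated at least 2.2-fold lower number from compound 1 to compound 3 (0.34 log units; beyond the scatter). For compound 3 the expected value is 45000 nM, with an estimated range of 15000 nM to 100000 nM.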

Compound 3, concentration for 50% growth inhibition: > 100000 nM
Compound 3: no number, only a limit; the forecaster's own chance of this, stated with the estimate: 30%; middle value at least 2.2-fold (0.34 log units) away from the limit.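

Compound 1 and compound 3 both give only a limit, not a number, in this assay, so no step between them can be read: the limit of > 100000 nM in this assay, at which 2 of the 3 values shown sit.

From the compounds shown here alone, whether (methoxycarbonyl)methyl in place of carboxy changes growth inhibition at all stays open.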